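The compounds below may be only part of what the source reports. "The series", "measured", "known", "first", "only" and "open" are said of these compounds alone.

Working notes on the series in a toxicity assay on HepG2 cells (Homo sapiens) for inhibition, read by CellTiter-Glo, with a stated time of 48 h; a higher number here means a weaker inhibitor, a lower number a stronger inhibitor. Compound 1 `COc1ccc2nc(C)cc(OCC(=O)Nc3ccccc3)c2c1` gives 39800 nM. Compound 2 `COc1ccc(NC(=O)COc2cc(C)nc3ccc(OC)cc23)cc1` reaches only the limit > 100000 nM, a limit of the assay rather than a number, in line with the limit of > 100000 nM in this assay, at which 1 of the 3 values shown sits. Compound 3 `COc1ccc2nc(C)cc(OCC(=O)Nc3c(C)cncc3C)c2c1` gives 12600 nM and stands lowest of the two numbers shown, its nearest neighbour being compound 1 through the step of a 3.2-fold lower number from compound 1 to compound 3 (0.50 log units; beyond the scatter). The other steps are an at least 2.5-fold higher number from compound 1 to compound 2 (0.40 log units; beyond the scatter) and an at least 7.9-fold lower number from compound 2 to compound 3 (0.89 log units; beyond the scatter), so every change at the amide-type nitrogen so far has moved this assay beyond the scatter, but only modestly.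

Compound 4 `COc1ccc2nc(C)cc(OCC(=O)Nc3nc(C)c(C)s3)c2c1` differs from compound 3 by 4,5-dimethyl-1,3-thiazol-2-yl in place of 3,5-dimethylpyridin-4-yl on an amide-type nitrogen. The three measured steps all concern the group on the amide-type nitrogen and therefore bear on this change, yet none exchanges a six-membered ring for a five-membered one, so the direction is open. Given that these steps were modest, the expected step is a 1.3-fold higher number from compound 3 to compound 4 (0.10 log units; within the scatter), within the scatter. Compound 4 is therefore estimated at 16000 nM, with a range from 5000 nM to 50000 nM.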

Compound 4, half-maximal inhibitory concentration: > 100000 nM
Compound 4 was reported as a limit (the forecaster's own chance of this, stated with the estimate: 10%); middle value at least 6.2-fold (0.79 log units) from the limit.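

In this assay, exchanging the six-membered 3,5-dimethylpyridin-4-yl for the five-membered 4,5-dimethyl-1,3-thiazol-2-yl on the amide-type nitrogen more than reverses the gain seen with compound 3, giving an at least 7.9-fold higher number from compound 3 to compound 4 (0.89 log units; beyond the scatter); the change from phenyl gives an at least 2.5-fold higher number from compound 1 to compound 4 (0.40 log units; beyond the scatter). Two methyl groups on the ring therefore do not by themselves lower the number at this position, since compound 3 and compound 4 both carry them and only compound 3 falls below compound 1. Compound 4 gives a limit of the assay rather than a number, and the step from compound 2, also a limit, cannot be read: the limit of > 100000 nM in this assay, at which 2 of the 4 values shown sit.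

Going by these compounds, how 4,5-dimethyl-1,3-thiazol-2-yl and 4-methoxyphenyl rank against each other remains open. Also open, on these data alone, is how this assay responds to an amine or a carboxylic acid in place of these rings on the amide-type nitrogen.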